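Swapping the phenyl for acetoxymethyl on a nucleoside core

This account rests on a few compounds, and the source may have more. Where it says the series, first, only, none or still open, it means among the compounds named here.

Of the compounds shown here, three sharing one core have been tested in a functional assay on A549 cells (Homo sapiens) for cytotoxicity, read by MTT assay, with a stated time of 72 h; on this read-out higher numbers stand for an effect only at larger amounts of compound and lower numbers for an effect already at smaller amounts. Compound 1, `CCS[C@@H]1[C@H](SCC)[C@@H](Cn2cc(-c3ccccc3)nn2)O[C@H]1n1ccc(=O)[nH]c1=O`, gives 3040 nM, the lowest of the three numbers. Compound 2, `CCS[C@@H]1[C@H](SCC)[C@@H](Cn2cc(-c3ccc(OC)cc3)nn2)O[C@H]1n1ccc(=O)[nH]c1=O`, gives 16800 nM, and compound 3, `CCS[C@@H]1[C@H](SCC)[C@@H](Cn2cc(-c3ccc(C)cc3)nn2)O[C@H]1n1ccc(=O)[nH]c1=O`, gives 6780 nM. Both changes to the phenyl raised the number: a 5.5-fold higher number from compound 1 to compound 2 (0.74 log units; beyond the scatter) and a 2.2-fold higher number from compound 1 to compound 3 (0.35 log units; beyond the scatter), while a 2.5-fold lower number from compound 2 to compound 3 (0.39 log units; beyond the scatter).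

Compound 4, `CCS[C@@H]1[C@H](SCC)[C@@H](Cn2cc(COC(C)=O)nn2)O[C@H]1n1ccc(=O)[nH]c1=O`, has not been measured in this assay. It differs from compound 1 as follows: acetoxymethyl in place of phenyl on an aromatic carbon. For the measured compounds named here, no measured step removes the phenyl altogether, so the two steps from compound 1 only show that altering this part of the molecule has so far given higher numbers, by modest amounts. A modest move in the same direction is therefore expected, with wide uncertainty, because of a 5.5-fold higher number from compound 1 to compound 2 (0.74 log units; beyond the scatter) and a 2.2-fold higher number from compound 1 to compound 3 (0.35 log units; beyond the scatter). The expected step is a 2.6-fold higher number from compound 1 to compound 4 (0.42 log units; beyond the scatter). For compound 4 the estimated value in this assay is 8000 nM, with a likely range from 2500 nM to 30000 nM.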

Compound 4, half-maximal effective concentration: >= 100000 nM
Compound 4: only a limit was reported; the forecaster's own chance of this, stated with the estimate: 15%; at least 12-fold (1.09 log units) between middle value and limit.
By their numbers in this assay, from the lowest: compound 1; then compound 3; then compound 2. At a limit, above all of these: compound 4.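

Compound 4 gives no number in this assay, only a limit of the assay: the limit of >= 100000 nM in this assay, at which 1 of the 4 values shown sits.

The earlier compounds shown here changed only a small group on the phenyl, whereas replacing the whole phenyl with acetoxymethyl gives an at least 32-fold higher number from compound 1 to compound 4 (1.51 log units; beyond the scatter), an at least 14-fold higher number from compound 3 to compound 4 (1.16 log units; beyond the scatter) and an at least 5.9-fold higher number from compound 2 to compound 4 (0.77 log units; beyond the scatter). For the compounds shown here, at this aromatic carbon of the five-membered aromatic ring with 3 nitrogen, the three compounds carrying a six-membered aromatic ring therefore all give measured numbers, while the one compound without such a ring reaches the limit.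

Going by these compounds, with only acetoxymethyl in place of the phenyl, it remains open whether losing the ring or bringing in this particular group matters more. Also open, on these data alone, is how this assay would read with a hydroxymethyl, an aminomethyl, a longer alkyl chain or a pyridine ring at this carbon.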